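From pyrimidin-4-yl to pyrimidin-2-yl in compound 4

A few compounds are considered here, and "the series" means these few. Any claim that something is new, unique, unknown or untested is made for them only; others in the source may bear on it.

Measured so far in a functional assay on Huh-7 cells (Homo sapiens) for cytotoxicity, read by MTT assay, with a stated time of 72 h (a lower number here means that less compound is tolerated, a higher number that more compound is tolerated), for three compounds
Compound 1 `CC(C)OC(=O)c1sc(Nc2ncccn2)nc1-c1ccccn1` gives 410 nM here
Compound 2 `CC(C)OC(=O)c1sc(Nc2ncccn2)nc1-c1cnccn1` gives 110 nM here
Compound 3 `CC(C)OC(=O)c1sc(Nc2ncccn2)nc1-c1ccncn1` gives 1210 nM here

Compound 3 holds the highest number of the three, with both gaps beyond the scatter. The still unmeasured compound 4 `CC(C)OC(=O)c1sc(Nc2ncccn2)nc1-c1ncccn1` has pyrimidin-2-yl in place of pyrimidin-4-yl on an aromatic carbon and otherwise keeps the shared core. Three swaps at this same carbon bear on it: a 3.7-fold lower number from compound 1 to compound 2 (0.57 log units; beyond the scatter), then a 3.0-fold higher number from compound 1 to compound 3 (0.47 log units; beyond the scatter), and an 11-fold higher number from compound 2 to compound 3 (1.04 log units; beyond the scatter) as the largest. With compound 3 at 1210 nM at the top of this range, a modest downward step is expected in this assay, and the estimated step is a 2.4-fold lower number from compound 3 to compound 4 (0.38 log units; beyond the scatter) overall. For compound 4 the estimate is 500 nM, with an expected range from 140 nM to 1800 nM overall.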

Compound 4, half-maximal cytotoxic concentration: 1620 nM
Beside the measured number, compound 4's estimate is 3.2-fold (0.51 log units) below it; low and high end bracket the measured number.
By their numbers in this assay, from the lowest: compound 2; then compound 1; then compounds 3 and 4 (each within the scatter of the next).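

In this assay, pyrimidin-2-yl in place of pyrimidin-4-yl makes no real difference at this carbon, with a 1.3-fold higher number from compound 3 to compound 4 (0.13 log units; within the scatter). The same group stands well apart from the two others tried here, with a 15-fold higher number from compound 2 to compound 4 (1.17 log units; beyond the scatter) as a large step and a 4.0-fold higher number from compound 1 to compound 4 (0.60 log units; beyond the scatter) as a modest one. Nothing available explains these differences. Still open, going by these compounds, is whether a phenyl ring or an amine on this carbon would give a number nearer compound 2 or compound 4. Also open, on these data alone, is whether the two pyrimidines would stay level with a carboxylic acid in place of the isopropoxycarbonyl group.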